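This account rests on a few compounds, and the source may have more. Where it says the series, first, only, none or still open, it means among the compounds named here.

Series notes on the shared core of compound 1 `CN1CCN(c2ccc(Nc3ncc4nc(Nc5ccc(F)cc5)n(CCNS(=O)(=O)C5CC5)c4n3)cc2)CC1`, compound 2 `CN1CCN(c2ccc(Nc3ncc4nc(Nc5ccccc5)n([C@H]5CCN(S(=O)(=O)C6CC6)C5)c4n3)cc2)CC1`, compound 3 `CN1CCN(c2ccc(Nc3ncc4nc(Nc5ccc(F)cc5)n(-c5cccc(NC(=O)CO)c5)c4n3)cc2)CC1` and compound 4 `CN1CCN(c2ccc(Nc3ncc4nc(Nc5ccc(F)cc5)n([C@H]5CCN(S(=O)(=O)C6CC6)C5)c4n3)cc2)CC1`, followed in a functional assay on A-431 cells (Homo sapiens) for antiproliferative activity, read by MTT assay, with a stated time of 72 h; on this read-out lower numbers stand for stronger inhibition and higher numbers for weaker inhibition.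

Compound 1 has no number in this assay; its result is recorded as "not determined" (no result reported). Compound 2 gives 1670 nM. Compound 3 gives 1670 nM, which is level with compound 2 at the digits shown and within the scatter of it; no word of order applies between these two.

The step from compound 3 to compound 4 is a single exchange on the aromatic nitrogen of the core: 1-(cyclopropylsulfonyl)pyrrolidin-3-yl in place of 3-(((hydroxymethyl)carbonyl)amino)phenyl on an aromatic nitrogen. The group that enters is the same 1-(cyclopropylsulfonyl)pyrrolidin-3-yl group that compound 2 carries, and compound 2 gives 1670 nM. Among the compounds with values here, no measured step of this kind is available, so the expected size of the change rests on the two values seen so far, both at the same level.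

On that basis compound 4 is expected to stay close to compound 3, with a step of a 1.1-fold lower number from compound 3 to compound 4 (0.05 log units; within the scatter) that is not expected to reach beyond the scatter in either direction. The estimate for compound 4 in this assay is 1500 nM, with a range from 500 nM to 5000 nM.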

Compound 4, half-maximal inhibitory concentration: 1670 nM
Beside the measured number, compound 4's estimate is 1.1-fold (0.05 log units) below it; the measured number falls inside the stated range.
By their numbers in this assay, from the lowest: compounds 2, 3 and 4 (each within the scatter of the next).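

In this assay, the exchange on the aromatic nitrogen of 3-(((hydroxymethyl)carbonyl)amino)phenyl for 1-(cyclopropylsulfonyl)pyrrolidin-3-yl gives no change at the digits printed from compound 3 to compound 4 (within the scatter) and so shows that two groups of 11 heavy atoms stand level at this position, although one has a six-membered aromatic ring of carbon only and 2 hydrogen-bond donors while the other has a three-membered and a five-membered non-aromatic ring and 0 hydrogen-bond donors. The second pair adds a reading at another place, where fluoro in place of hydrogen on an aromatic carbon gives no change at the digits printed from compound 2 to compound 4 (within the scatter) and the (4-fluorophenyl)amino group does not separate compound 4 from compound 2 with 1-(cyclopropylsulfonyl)pyrrolidin-3-yl on the nitrogen. No supporting data bear on why these values stand level.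

The compounds shown leave open whether a primary amine or a carboxylic acid on this aromatic nitrogen would stay level with these values or move beyond the scatter. They also leave open whether the opposite configuration at the defined stereocentre of the pyrrolidine would read the same.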